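The compounds below may be only part of what the source reports. "The series", "measured", "known", "first", "only" and "open" are said of these compounds alone.

Measured so far:
compound 1 `CCN(Cc1ccccc1)C(=O)C1CCN(S(=O)(=O)c2cccc(OC)c2)CC1` – 77%
compound 2 `CCN(Cc1ccccc1)C(=O)C1CCN(S(=O)(=O)c2c(C)noc2C)CC1` – "not determined" (no result reported)

Among the measured compounds shown here, in a functional assay on CHO cells for positive allosteric modulation of muscarinic acetylcholine receptor M5 (Homo sapiens), read by calcium flux (on this read-out higher numbers stand for larger maximal responses and lower numbers for smaller maximal responses), compound 1 gives 77%; it is the only number, as compound 2 has no result. Compound 3 `CCN(Cc1ccccc1)C(=O)C1CCN(S(=O)(=O)c2ccc3cccnc3c2)CC1` carries quinolin-7-yl in place of 3-methoxyphenyl on a sulfonyl sulfur. For the measured compounds named here, with no comparable step measured, the size of the change is open; the expectation is a step from compound 1 to compound 3 of a number 7 percentage points lower from compound 1 to compound 3 (within the scatter), small and likely within the scatter, if anything downward. Compound 3 is thus estimated at 70%, with a range from 40% to 100%.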

Compound 3, largest response reached (reported as percent of maximum), in percent of the reference or control that the assay uses: 66%
Compound 3: middle estimate off by 4 percentage points, on the high side; low and high end bracket the measured number.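

In this assay quinolin-7-yl in place of 3-methoxyphenyl on a sulfonyl sulfur gives a number 11 percentage points lower from compound 1 to compound 3 (beyond the scatter) and thus a modest loss, so this position keeps a sizeable maximal response with a two-ring aromatic group. No measurement at hand explains the loss.

This single pair cannot separate the loss of the methoxy group from the gain of the second ring and its nitrogen, and steps involving compound 2 cannot be read. On these data alone, how plain phenyl, or a phenyl bearing a carboxylic acid or an amine, would behave on this sulfur remains open.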